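The source may report more compounds than this note shows. Statements on the series, on what has been measured and on what is new or still open speak of the compounds shown alone.

Compound 2 `C=C(Br)C(=O)Nc1ccc(/C=C2\SC(=O)N(Cc3ccc(C(F)(F)F)cc3)C2=O)cc1` carries a (1-bromoethenyl)carbonyl group on the aniline nitrogen; in a functional assay on HeLa cells (Homo sapiens) for cytotoxicity, read by cell counting, with a stated time of 4 days (a higher number here means a weaker inhibitor, a lower number a stronger inhibitor), compound 2 gives 13000 nM, the lower of the two numbers seen so far. Its parent, compound 1 `Nc1ccc(/C=C2\SC(=O)N(Cc3ccc(C(F)(F)F)cc3)C2=O)cc1`, gives 96000 nM in this assay, and a 7.4-fold lower number from compound 1 to compound 2 (0.87 log units; beyond the scatter). Compound 3 `C=C(Br)C(=O)Nc1ccc(/C=C2\SC(=O)N(Cc3ccc(F)cc3)C2=O)cc1` keeps that acyl group and alters only the 4-(trifluoromethyl)phenyl group: fluoro in place of trifluoromethyl on an aromatic carbon. Among the measured compounds shown here, no measured step touches this part of the molecule, so nothing beyond the usual scatter is expected either way. Compound 3 is therefore estimated at 15000 nM, within 4000 nM to 50000 nM, meaning an expected 1.2-fold higher number from compound 2 to compound 3 (0.06 log units; within the scatter).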

Compound 3, half-maximal inhibitory concentration: 2000 nM
Estimate against measurement, compound 3: 7.5-fold (0.88 log units) above, and the stated range ends above it.
By their numbers in this assay, from the lowest: compound 3; then compound 2; then compound 1.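

Among the compounds shown here, the 4-(trifluoromethyl)phenyl end of the molecule, which no earlier step had touched, turns out to matter in this assay: with the acyl group on the aniline nitrogen held fixed, fluoro in place of trifluoromethyl gives a 6.5-fold lower number from compound 2 to compound 3 (0.81 log units; beyond the scatter) and so this end can shift the number as well. This is a single pair, so it shows one change at one position and no general trend. Nothing measured here explains the step. On these data alone, whether hydrogen, chloro or a methoxy group at this position would track compound 2 or compound 3 stays open, as does whether fluoro would give a similar shift on the free aniline of compound 1.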